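This account rests on a few compounds, and the source may have more. Where it says the series, first, only, none or still open, it means among the compounds named here.

In a functional assay on SGC-7901 cells (Homo sapiens) for inhibition, read by MTT assay, with a stated time of 24 h (a higher number here means a weaker inhibitor, a lower number a stronger inhibitor), three compounds have been measured:

Compound 1 `CC1(C)[C@H]2CC[C@]1(C)N(Cc1cn(-c3ccccc3Br)nn1)C(=O)C2` gives 500 nM
Compound 2 `CC1(C)[C@H]2CC[C@]1(C)N(Cc1cn(-c3ccc(O)cc3)nn1)C(=O)C2` gives 330 nM
Compound 3 `CC1(C)[C@H]2CC[C@]1(C)N(Cc1cn(-c3cccc(O)c3)nn1)C(=O)C2` gives 270 nM

Compound 3 stands at 270 nM in this assay and cannot be separated from the other two compounds on these numbers, with a 1.2-fold lower number from compound 2 to compound 3 (0.09 log units; within the scatter) and a 1.9-fold lower number from compound 1 to compound 3 (0.27 log units; within the scatter) as the measured steps.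

Compound 4 `Cc1cccc(-n2cc(CN3C(=O)C[C@@H]4CC[C@@]3(C)C4(C)C)nn2)c1` alters one group of compound 3, with methyl in place of hydroxy on an aromatic carbon as the counted difference: methyl in place of hydroxy on an aromatic carbon, so that 3-hydroxyphenyl becomes 3-methylphenyl.

Going by the values given here, no measured step makes this exact exchange, so the evidence is indirect. The closest guide is the set of other changes to the same phenyl group, namely a 1.5-fold lower number from compound 1 to compound 2 (0.18 log units; within the scatter) together with the two steps above, and none of them goes beyond the scatter. On that basis, no step beyond the scatter is expected in this assay, and these three compounds give no firm direction.

The estimated step is a 1.3-fold higher number from compound 3 to compound 4 (0.11 log units; within the scatter) and remains a modest expectation only.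

For compound 4 the estimated value is 350 nM with an expected range from 150 nM to 800 nM as the likely span.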

Compound 4, half-maximal inhibitory concentration: 410 nM
Estimate against measurement, compound 4: 1.2-fold (0.07 log units) below, and the stated range covers the measured number.
By their numbers in this assay, from the lowest: compounds 3, 2, 4 and 1 (each within the scatter of the next).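

In this assay, exchanging hydroxy for methyl on the 3-hydroxyphenyl group, which removes its hydrogen-bond donor and acceptor, gives a 1.5-fold higher number from compound 3 to compound 4 (0.18 log units; within the scatter), so on these numbers a hydroxy at this place is not required to remain within the scatter of compound 3. The earlier compounds shown here compared hydroxy only at another place on the ring or against a 2-bromophenyl group, whereas this pair isolates the hydroxy itself, and the new 3-methylphenyl group also cannot be separated from the other two groups, with a 1.2-fold higher number from compound 2 to compound 4 (0.09 log units; within the scatter) and a 1.2-fold lower number from compound 1 to compound 4 (0.09 log units; within the scatter). No measurement available here explains these numbers.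

All four phenyl groups shown fall within the scatter of their neighbours, so it remains open whether any substituent at this place can produce a step beyond the scatter, and an amine, a carboxylic acid or a longer alkyl chain would test this. The compounds shown also leave open whether the same holds with the phenyl group replaced by a pyridine or with the shared core altered.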